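Pyrrolidinyl-acetamide in place of phenol on the shared core

This account rests on a few compounds, and the source may have more. Where it says the series, first, only, none or still open, it means among the compounds named here.

Measured compounds:
- compound 1 `Oc1ccc(-c2nc3cc(C(F)(F)F)ccc3[nH]2)cc1`: 17000 nM
- compound 2 `COc1ccc(-c2nc3cc(Cl)c(Cl)cc3[nH]2)c([N+](=O)[O-])c1`: 2000 nM
- compound 3 `CC(=O)Nc1ccc(-c2nc3cc(C(F)(F)F)ccc3n2C2CCCCC2)cc1`: 24000 nM

The numbers come from an ADME assay on MT4 cells (Homo sapiens) for cytotoxicity, read by MTT assay, with a stated time of 96 h; a higher number here means that more compound is tolerated, a lower number that less compound is tolerated. Compound 1 stands second highest of the three. Its nearest neighbour is compound 3, whose number is within the scatter of that of compound 1, so no order between these two is claimed. Compound 2 is furthest away, with a number well beyond the scatter below that of compound 1, so compound 2 is the least tolerated of the three. No pair of these compounds differs in one place only, so no single step can be read off.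

The step under consideration leads from compound 1 to compound 4 `O=C(CN1CCCC1)Nc1ccc(-c2nc3cc(C(F)(F)F)ccc3[nH]2)cc1`. The change: (((pyrrolidin-1-yl)methyl)carbonyl)amino in place of hydroxy on an aromatic carbon. The entering group sits on an aromatic carbon of a six-membered aromatic ring of carbon only, para to a large group.

For the measured compounds named here, with no measured step that isolates such a change, the expectation rests on what the three numbers show. Compound 3, which carries an acylated amino group on the same kind of ring, gives 24000 nM in this assay, within the scatter of compound 1. The step from compound 1 to compound 4 is therefore expected to be small, a 1.1-fold lower number from compound 1 to compound 4 (0.05 log units; within the scatter), none beyond the scatter in either direction. For compound 4 the estimate is 15000 nM, with a range from 6000 nM to 40000 nM.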

Compound 4, half-maximal cytotoxic concentration: 18000 nM
Compound 4: the middle estimate sits 1.2-fold (0.08 log units) below what was measured; measured number inside the range.
By their numbers in this assay, from the lowest: compound 2; then compounds 1, 4 and 3 (each within the scatter of the next).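

Swapping hydroxy for (((pyrrolidin-1-yl)methyl)carbonyl)amino on an aromatic carbon, para to a large group, gives in this assay the first step isolating one place in this series: a 1.1-fold higher number from compound 1 to compound 4 (0.02 log units; within the scatter), with the rest of the core of compound 1 unchanged. The earlier compounds shown here differed in several places at once, whereas this pair shows directly that, on this core, a group of 9 heavy atoms carrying a five-membered non-aromatic ring can stand at this position in place of a single oxygen with no difference in tolerated concentration that can be claimed. Nothing measured here bears on why the step has this size.

On these data alone, it remains open whether a plain acetamide, a morpholine or piperidine ring in place of pyrrolidine, a dimethylamino group or a longer chain between the carbonyl and the amine would sit equally close to compound 1 in this assay. Also open, as far as these compounds go, is whether the same exchange would behave alike with the two chlorines of compound 2 or the cyclohexyl group of compound 3 on the shared core.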